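Swapping Methoxy for Chloro on a Cell-Growth Inhibitor

The compounds below may be only part of what the source reports. "The series", "measured", "known", "first", "only" and "open" are said of these compounds alone.

Of the compounds shown here, three built on a shared core have been tested in a functional assay on SK-MEL-2 cells (Homo sapiens) for inhibition; a lower number here means a stronger inhibitor of growth, a higher number a weaker inhibitor of growth. Compound 1 `COc1cc(/C=C/C(=O)c2cccc(-n3cc(-c4ccccc4)[nH]c3=O)c2)ccc1O` gives 3650 nM. Compound 2 `O=C(/C=C/c1cccc(O)c1)c1cccc(-n2cc(-c3ccc(Cl)cc3)[nH]c2=O)c1` gives 2070 nM in this assay. Compound 3 `COc1ccc(-c2cn(-c3cccc(C(=O)/C=C/c4ccc(O)c(OC)c4)c3)c(=O)[nH]2)cc1` gives 5540 nM, the highest of the three numbers: its gap to compound 1 lies within the scatter, while its gap to compound 2 lies beyond it.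

Within the data shown here, only one pair of measured compounds differs in a single place: a 1.5-fold higher number from compound 1 to compound 3 (0.18 log units; within the scatter), a methoxy in place of hydrogen on an aromatic carbon. That step stayed within the scatter.

Compound 4 `COc1cc(/C=C/C(=O)c2cccc(-n3cc(-c4ccc(Cl)cc4)[nH]c3=O)c2)ccc1O` is compound 3 with chloro in place of methoxy on an aromatic carbon. The step from compound 1 to compound 3 shows that this position accepts methoxy versus hydrogen without a change beyond the scatter, so removing the methoxy is unlikely by itself to move the number much. Among the measured compounds shown here, no measured step introduces chloro at this position with everything else held fixed; compound 2 carries the same chloro-bearing ring but differs from compound 3 elsewhere as well, so its value shows only what that whole combination gives. The expected step is therefore a 2.0-fold lower number from compound 3 to compound 4 (0.30 log units; within the scatter), a lower number, though one that may still fall within the scatter. Compound 4 is estimated at 2800 nM, with a range from 1100 nM to 7000 nM.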

Compound 4, concentration for 50% growth inhibition: 3660 nM
Beside the measured number, compound 4's estimate is 1.3-fold (0.12 log units) below it, within the range that was stated.
By their numbers in this assay, from the lowest: compounds 2, 1, 4 and 3 (each within the scatter of the next, the first and the last beyond it).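

In this assay, going from 4-methoxyphenyl to 4-chlorophenyl gives a step that stays within the scatter (a 1.5-fold lower number from compound 3 to compound 4 (0.18 log units; within the scatter)), so chloro and methoxy cannot be told apart at this position. Among these compounds, compound 4 also gives the first direct reading of chloro against hydrogen on this aromatic carbon (a 1.0-fold higher number from compound 1 to compound 4 (0.00 log units; within the scatter)), and together with the earlier methoxy step (a 1.5-fold higher number from compound 1 to compound 3 (0.18 log units; within the scatter)) it shows that neither group moves the number beyond the scatter from the hydrogen of compound 1. With chloro held fixed, the ring at the other end of the chain can also change, with 4-hydroxy-3-methoxyphenyl in place of 3-hydroxyphenyl, and that step too stays within the scatter (a 1.8-fold higher number from compound 2 to compound 4 (0.25 log units; within the scatter)).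

No measurement available here offers an explanation for these small steps. Only hydrogen, methoxy and chloro are shown at this position, so it remains open whether an amine, a carboxylic acid or a longer chain there would move the number beyond the scatter.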